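A few compounds are considered here, and "the series" means these few. Any claim that something is new, unique, unknown or untested is made for them only; others in the source may bear on it.

The measured compounds in an ADME assay on microsomes from liver (Rattus norvegicus) for metabolic stability, with a stated time of 10 min (on this read-out lower numbers stand for a less stable compound and higher numbers for a more stable compound), are these
- Compound 1 `FC(F)(F)c1ccccc1-c1ccc2[nH]c(C3=NOC4(CCCCC4)C3)nc2c1` gives 75%
- Compound 2 `FC(F)(F)Oc1ccccc1-c1ccc2[nH]c(C3=NOC4(CCCCC4)C3)nc2c1` gives 74%
- Compound 3 `Fc1cccc(C(F)(F)F)c1-c1ccc2[nH]c(C3=NOC4(CCCCC4)C3)nc2c1` gives 37%

Compound 1 stands with compound 2 at the upper end of these three numbers, the two lying within the scatter of each other, while compound 3 lies well under them. Compound 4 `OCCCc1cc(-c2ccccc2C(F)(F)F)cc2nc(C3=NOC4(CCCCC4)C3)[nH]c12` has not yet been measured. It differs from compound 1 by one change (3-hydroxypropyl in place of hydrogen on an aromatic carbon), namely 3-hydroxypropyl in place of hydrogen on an aromatic carbon, meta to a 2-(trifluoromethyl)phenyl group.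

Two measured steps can be weighed against this change. The first, a number 1 percentage points lower from compound 1 to compound 2 (within the scatter), exchanges trifluoromethyl for trifluoromethoxy and replaces no hydrogen, so it says little here. The second, a number 38 percentage points lower from compound 1 to compound 3 (beyond the scatter), is the only measured case of a hydrogen on an aromatic carbon being replaced, here by fluoro, and it is large. It involves a different group at a different place, so it is only a loose guide. Going by the values given here, no measured compound carries a 3-hydroxypropyl. A fall beyond the scatter is expected, though somewhat smaller than that second step. The step expected is a number 25 percentage points lower from compound 1 to compound 4 (beyond the scatter) in this estimate. For compound 4 the estimated value is 50% with an expected range from 25% to 72% in this assay as the likely outcome.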

Compound 4, percent of the compound remaining: 74%
The estimate for compound 4 lay 24 percentage points below the measured number; the measured number lies above the stated range.
By their numbers in this assay, from the lowest: compound 3; then compounds 2, 4 and 1 (each within the scatter of the next).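

In this assay, placing a 3-hydroxypropyl chain on the aromatic carbon meta to a 2-(trifluoromethyl)phenyl group gives a number 1 percentage points lower from compound 1 to compound 4 (within the scatter), so this position accepts a chain of this size with the read-out staying within the scatter. The only earlier replacement of a hydrogen on an aromatic carbon, a number 38 percentage points lower from compound 1 to compound 3 (beyond the scatter), put fluoro at a different place, and its large size therefore does not extend to this position and this group. Nothing measured here accounts for why the chain leaves the read-out within the scatter while the fluoro step does not.

The compounds shown leave open whether a longer chain, or a chain ending in an amine or a carboxylic acid instead of a hydroxyl, would stay within the scatter of compound 1 on this same carbon. They also leave open how fluoro would behave on this carbon and how 3-hydroxypropyl would behave at the place that carries fluoro in compound 3, so the roles of group and position in these two steps cannot yet be separated.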